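The compounds below may be only part of what the source reports. "The series", "measured", "known", "first", "only" and "open" are said of these compounds alone.

Compound 3 `CC(C)(C)c1ccc(/C=C/C(=O)c2ccc(OCC(=O)N[C@H]3CCOC3=O)cc2)cc1` gives the highest number of the three measured in a functional assay on PC-3 cells (Homo sapiens) for antiproliferative activity, read by MTT assay, with a stated time of 72 h (a lower number here means a stronger inhibitor, a higher number a weaker inhibitor), at 10600 nM. Compound 1 `O=C(COc1ccc(C(=O)/C=C/c2ccccc2Cl)cc1)N[C@H]1CCOC1=O` gives 4610 nM and compound 2 `COc1ccccc1/C=C/C(=O)c1ccc(OCC(=O)N[C@H]2CCOC2=O)cc1` gives 7240 nM in this assay. The steps of a 2.3-fold higher number from compound 1 to compound 3 (0.36 log units; beyond the scatter) and a 1.5-fold higher number from compound 2 to compound 3 (0.17 log units; within the scatter) each exchange the whole aryl group on the chain, while a 1.6-fold higher number from compound 1 to compound 2 (0.20 log units; within the scatter) swaps substituents on that ring. Compound 4 `CC(C)c1ccc(/C=C/C(=O)c2ccc(OCC(=O)N[C@H]3CCOC3=O)cc2)cc1` differs from compound 3 by hydrogen in place of methyl on a saturated chain carbon bound to an aromatic carbon and two saturated chain carbons. Within the data shown here, no measured step shortens the alkyl group on the aryl in this way, so nothing bears on it directly; the measured steps were at most modest. The expected step of a 1.2-fold lower number from compound 3 to compound 4 (0.07 log units; within the scatter) is therefore none beyond the scatter. Compound 4 is expected to give about 9000 nM in this assay, between 4500 nM and 18000 nM.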

Compound 4, half-maximal inhibitory concentration: 4660 nM
Compound 4: middle estimate off by 1.9-fold (0.29 log units), on the high side; low and high end bracket the measured number.
By their numbers in this assay, from the lowest: compounds 1, 4, 2 and 3 (each within the scatter of the next, the first and the last beyond it).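

In this assay, among these compounds, hydrogen in place of methyl on this saturated chain carbon is not silent: a 2.3-fold lower number from compound 3 to compound 4 (0.36 log units; beyond the scatter), the first measured step confined to the alkyl group on the aryl. The 4-isopropylphenyl group cannot be separated from either ring substituted at another place, with a 1.6-fold lower number from compound 2 to compound 4 (0.19 log units; within the scatter) and a 1.0-fold higher number from compound 1 to compound 4 (0.00 log units; within the scatter). No evidence on hand accounts for the effect of this methyl. Open, as far as these compounds go, is how an ethyl or a methyl in place of the isopropyl would read. Also open, from the compounds shown here alone, is whether an amine or a carboxylic acid there would be tolerated.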